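The source may hold more compounds than are shown below. What is called first, only, known or untested is meant among the compounds shown, and "the series" means these compounds.

Of the compounds shown here, two of a shared core have been measured in a functional assay on the whole organism (strain Wister albino) for inhibition, with Rattus norvegicus as the target, read by paw edema, with stated times of 1 h and 2 h, at a dose of 50 mg/kg by the intraperitoneal route; on this read-out higher numbers stand for more inhibition at the one dose given (going by the name of the read-out) and lower numbers for less inhibition. Compound 1 `Cc1ccc([C@@H]2CN(C)[C@]3(C(=O)Nc4ccccc43)[C@]23Cc2ccccc2C3=O)cc1` gives 23.8% in this assay. Compound 2 `CN1C[C@@H](c2ccco2)[C@@]2(Cc3ccccc3C2=O)[C@@]12C(=O)Nc1ccccc12` gives 53.6% in this assay, and it stands highest of the two numbers, its nearest neighbour being compound 1. Among the measured compounds shown here, the one measured step, a number 29.8 percentage points higher from compound 1 to compound 2 (beyond the scatter), moves from a 4-methylphenyl group to a furan-2-yl group on the saturated ring carbon. Compound 3 `COc1ccc([C@@H]2CN(C)[C@]3(C(=O)Nc4ccccc43)[C@]23Cc2ccccc2C3=O)cc1` is not yet measured; it differs from compound 2 in one place: 4-methoxyphenyl in place of furan-2-yl on a saturated ring carbon. That change reverses the earlier step in its ring type, putting a six-membered aromatic ring of carbon only back where the five-membered ring with one hetero atom was, though now carrying a methoxy group rather than a methyl group. Because a number 29.8 percentage points higher from compound 1 to compound 2 (beyond the scatter) was modest but beyond the scatter, the return to a six-membered carbon ring is expected to give back a fair part of that gain, with the methoxy group leaving some uncertainty. Compound 3 is therefore expected to show a step of a number 23.6 percentage points lower from compound 2 to compound 3 (beyond the scatter). The estimate for compound 3 in this assay is 30%, within a range from 15% to 48%.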

Compound 3, a percentage reported as inhibition, in the whole organism at one dose (the size of the read-out at that dose, not a potency): 17.5%
Compound 3: middle estimate off by 12.5 percentage points, on the high side; measured number inside the range.
By their numbers in this assay, from the lowest: compounds 3 and 1 (each within the scatter of the next); then compound 2.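

In this assay, the saturated ring carbon responds to the type of ring placed on it: 4-methoxyphenyl in place of furan-2-yl gives a number 36.1 percentage points lower from compound 2 to compound 3 (beyond the scatter), so the gain seen with furan-2-yl is now set against two six-membered carbon rings rather than one. Methoxy in place of methyl on the aromatic carbon of that six-membered ring gives a number 6.3 percentage points lower from compound 1 to compound 3 (within the scatter), so this change on the phenyl ring does not separate compound 1 from compound 3 at this single dose, and among these three compounds only the furan-2-yl group stands apart. The data offer no measured explanation for this difference.

The compounds shown leave open whether the higher number follows the five-membered ring, its oxygen atom or simply the absence of a group on the ring, a question that thiophen-2-yl or an unsubstituted phenyl could help to separate. They also leave open how a pyridine ring, or a phenyl ring carrying an amine or a carboxylic acid, would behave at this position, and whether the same order would hold at other doses.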